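Chloro added to the benzoxazole of compound 2

This account rests on a few compounds, and the source may have more. Where it says the series, first, only, none or still open, it means among the compounds named here.

Working notes. Compound 1 `Cn1c(-c2ccc(NC(=O)CCl)cc2)nc(-c2ccccc2)c1-c1ccccc1` and compound 2 `Cn1c(-c2ccc(NC(=O)CSc3nc4ccccc4o3)cc2)nc(-c2ccccc2)c1-c1ccccc1` share one core. In a functional assay on MCF7 cells (Homo sapiens) for cytotoxicity, read by MTT assay, with a stated time of 24 h, tested at 80 ug/mL (on this read-out higher numbers stand for a stronger effect at the one concentration tested and lower numbers for a weaker effect), compound 1 gives 70%, and compound 2 gives 76.3%. The single measured step, a number 6.3 percentage points higher from compound 1 to compound 2 (within the scatter), lies within the scatter, so on the two numbers shown compound 2 is not separated from compound 1.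

Compound 3 `Cn1c(-c2ccc(NC(=O)CSc3nc4cc(Cl)ccc4o3)cc2)nc(-c2ccccc2)c1-c1ccccc1` differs from compound 2 by chloro in place of hydrogen on an aromatic carbon. Among the measured compounds shown here, no measured step concerns the 1,3-benzoxazol-2-yl group itself; the only step in hand, a number 6.3 percentage points higher from compound 1 to compound 2 (within the scatter), replaced the group on the saturated chain carbon bound to the carbonyl carbon and stayed within the scatter. The numbers therefore give no basis for a step beyond the scatter in this assay in either direction, and the expected step is a number 0.3 percentage points lower from compound 2 to compound 3 (within the scatter). Compound 3 is accordingly estimated at 76%, with a range from 60% to 88%.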

Compound 3, a percentage reported as activity, at one concentration (the size of the read-out at that concentration, not a potency): 69.1%
Beside the measured number, compound 3's estimate is 6.9 percentage points above it; low and high end bracket the measured number.
By their numbers in this assay, from the lowest: compounds 3, 1 and 2 (each within the scatter of the next).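

In this assay, among the compounds shown here, the first change on the 1,3-benzoxazol-2-yl group itself, chloro in place of hydrogen on an aromatic carbon, gives a number 7.2 percentage points lower from compound 2 to compound 3 (within the scatter), so 5-chloro-1,3-benzoxazol-2-yl is not separated from the unsubstituted group on this read-out. The step of a number 0.9 percentage points lower from compound 1 to compound 3 (within the scatter) is also within the scatter, so (5-chloro-1,3-benzoxazol-2-yl)sulfanyl is not separated from chloro on the saturated chain carbon bound to the carbonyl carbon, and all three compounds remain level in this assay. No measured information is available to explain this result.

Still open, going by these compounds, is whether a different substituent at this aromatic carbon, such as an amine or a carboxylic acid, would give a step beyond the scatter. Also open, on these data alone, is whether a longer chain between the sulfanyl and the carbonyl carbon would separate these compounds, and whether their concentration dependence differs, since a single concentration gives no potency.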